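Swapping Nitrophenyl for Furan in a Cell Toxicity Screen

A few compounds are considered here, and "the series" means these few. Any claim that something is new, unique, unknown or untested is made for them only; others in the source may bear on it.

Compound 1, `COc1ccccc1C1CC(c2cc3ccccc3o2)=NN1C(=O)c1ccncc1`, gives > 202000 nM in an ADME assay on Vero cells (Chlorocebus sabaeus) for cytotoxicity, read by MTT assay, with a stated time of 72 h (a lower number here means a stronger inhibitor, a higher number a weaker inhibitor), which is a limit of the assay rather than a number.
Compound 2, `O=C(c1ccncc1)N1N=C(c2cc3ccccc3o2)CC1c1cccc([N+](=O)[O-])c1`, gives > 240000 nM in this assay, again a limit.
Compound 3, `O=C(c1ccncc1)N1N=C(c2cc3ccccc3o2)CC1c1ccccc1Cl`, gives > 210000 nM in this assay, again a limit.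

Compound 2 therefore stands only at a limit, and the other two values are limits as well. Compound 4, `O=C(c1ccncc1)N1N=C(c2cc3ccccc3o2)CC1c1ccco1`, differs from it by furan-2-yl in place of 3-nitrophenyl on a saturated ring carbon. Among the measured compounds shown here, the steps that bear on this change are a step that the two limits leave unreadable from compound 2 to compound 3 and a step that the two limits leave unreadable from compound 1 to compound 2; neither size can be read, since both ends of each sit at limits. No direction can be inferred from them. Compound 4 is therefore expected to give 250000 nM, with a range of 100000 nM to 600000 nM, most likely again as a limit. This expectation corresponds to a step that the limit leaves unreadable from compound 2 to compound 4.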

Compound 4, half-maximal inhibitory concentration: > 208000 nM
Compound 4: only a limit was reported; the forecaster's own chance of this, stated with the estimate: 85%; the middle value does not contradict the limit.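

Compound 4 gives a limit, as do compounds 1, 2 and 3, so no step among these four compounds can be read in this assay. The compounds shown leave open whether changing the group on the saturated ring carbon alters the result at all.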